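Butyl gives way to trifluoromethyl: expectations for compound 4

This account rests on a few compounds, and the source may have more. Where it says the series, first, only, none or still open, it means among the compounds named here.

Going by the values given here, in a functional assay on the whole organism (strain Kunming) for inhibition, with Mus musculus as the target, with a stated time of 1 h, at a dose of 40 mg/kg by the oral route (a lower number here means less inhibition, a higher number more inhibition at the dose given (going by the name of the read-out)), compound 3 `CCCCc1ccc(S(=O)(=O)N2CCN(c3ccc(C(=O)/C=C/c4ccccc4)cc3)CC2)cc1` gives 24%, the lowest of the three numbers known. Compound 2 `O=C(/C=C/c1ccccc1)c1ccc(N2CCN(S(=O)(=O)c3ccccc3)CC2)cc1` gives 30% in this assay, and compound 1 `O=C(/C=C/c1ccc(Cl)cc1)c1ccc(N2CCN(S(=O)(=O)c3ccc(C(F)(F)F)cc3)CC2)cc1` gives 59.6%; the gap to compound 1 lies beyond the scatter, while that to compound 2 lies within it. Compound 4 `O=C(/C=C/c1ccccc1)c1ccc(N2CCN(S(=O)(=O)c3ccc(C(F)(F)F)cc3)CC2)cc1` differs from compound 3 by trifluoromethyl in place of butyl on an aromatic carbon. Among the compounds with values here, the only measured step at the same position, a number 6 percentage points lower from compound 2 to compound 3 (within the scatter), stayed within the scatter. Within the data shown here, no measured pair shows trifluoromethyl in place of butyl alone; compound 1 carries trifluoromethyl but also a chlorine, so its value is only a hint. Compound 4 is therefore expected to gain somewhat, by a number 16 percentage points higher from compound 3 to compound 4 (beyond the scatter). The estimate for compound 4 is 40%, within 20% to 60%.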

Compound 4, a percentage reported as inhibition, in the whole organism at one dose (the size of the read-out at that dose, not a potency): 47.9%
Compound 4: middle estimate off by 7.9 percentage points, on the low side; the range from low to high includes it.
By their numbers in this assay, from the lowest: compounds 3 and 2 (each within the scatter of the next); then compound 4; then compound 1.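

In this assay this position, para to a large group, proved responsive: trifluoromethyl in place of butyl gave a number 23.9 percentage points higher from compound 3 to compound 4 (beyond the scatter) and trifluoromethyl in place of hydrogen gave a number 17.9 percentage points higher from compound 2 to compound 4 (beyond the scatter) while butyl in place of hydrogen had stayed within the scatter. Hydrogen in place of chloro gave a number 11.7 percentage points lower from compound 1 to compound 4 (beyond the scatter) so the chloro group elsewhere in compound 1 registers on this read-out as well. Going by these compounds, whether an amine, a nitrile or a carboxylic acid at the same position would match trifluoromethyl stays open. Why these steps arise also stays open, as nothing available speaks to their cause.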